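A Hydroxy Group Tested Against a Cytotoxicity Ceiling

A few compounds are considered here, and "the series" means these few. Any claim that something is new, unique, unknown or untested is made for them only; others in the source may bear on it.

Compound 1 `CCNC(=O)c1cc2c(Nc3ccc(OC(F)(F)F)cc3)ncnc2s1` was tested in an ADME assay on BaF3 cells (Mus musculus) for cytotoxicity; a higher number here means that more compound is needed for the effect, a lower number that less compound is needed. In this assay compound 1 gives > 10000 nM, which is a limit of the assay rather than a number. Compound 2 `O=C(NCCO)c1cc2c(Nc3ccc(OC(F)(F)F)cc3)ncnc2s1` differs from compound 1 by a single change: hydroxy in place of hydrogen on a saturated chain carbon, two bonds along the chain from an amide-type nitrogen. In this assay compound 2 gives > 10000 nM, again a limit. The step that the two limits leave unreadable from compound 1 to compound 2 therefore has no readable size. Compound 3 `CCn1ncc2c(Nc3ccc(OC(F)(F)F)cc3)ncnc21` is built on a different core; how that core differs from the core of compound 1 is not broken down here. In this assay compound 3 gives > 10000 nM, also a limit. What the three measurements share is the limit of > 10000 nM in this assay, at which 3 of the 3 values shown sit.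

Compound 4 `OCCn1ncc2c(Nc3ccc(OC(F)(F)F)cc3)ncnc21` has not yet been measured. It differs from compound 3 by hydroxy in place of hydrogen on a saturated chain carbon, two bonds along the chain from an aromatic nitrogen. Among the measured compounds shown here, this is the same kind of change as the one from compound 1 to compound 2, though not the same: in compound 1 the carbon that takes the hydroxy sits two bonds along the chain from an amide-type nitrogen, whereas in compound 3 it sits two bonds along the chain from an aromatic nitrogen. Because the limit of > 10000 nM in this assay, at which 3 of the 3 values shown sit, holds every measured value at the ceiling, the step from compound 1 to compound 2 could not be sized. Compound 4 is expected to stay at that ceiling too, so the step that the limit leaves unreadable from compound 3 to compound 4 is estimated to be no larger than the earlier one allows. Compound 4 is expected to give 15000 nM, most likely reported as a limit, in a range from 8000 nM to 40000 nM.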

Compound 4, half-maximal effective concentration: > 10000 nM
Compound 4: only a limit was reported (the forecaster's own chance of this, stated with the estimate: 90%); the middle value lies beyond the limit too.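

In this assay compound 4 gives > 10000 nM as a limit of the assay, not a number. The size of the step from compound 3 to compound 4 therefore cannot be read, and neither can that of the step from compound 1 to compound 2. The compounds shown leave open how much of each is needed for the effect, and whether hydroxy in place of hydrogen alters that amount at all, because every result stops at the same ceiling: the limit of > 10000 nM in this assay, at which 4 of the 4 values shown sit.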